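Series notes: aryl variation on the shared core

The source may report more compounds than this note shows. Statements on the series, on what has been measured and on what is new or still open speak of the compounds shown alone.

Measured compounds:
compound 1 `O=Cc1ccc(-c2cn3ccnc3c(-c3ccc4ncn(C5CCCCC5)c4c3)n2)cc1` — 45.5%
compound 2 `c1ccc2c(-c3cn4ccnc4c(-c4ccc5ncn(C6CCCCC6)c5c4)n3)cccc2c1` — 3.62%
compound 3 `Fc1ccc(-c2cn3ccnc3c(-c3ccc4ncn(C5CCCCC5)c4c3)n2)cc1` — 17.6%

In a functional assay on Hs-578T cells (Homo sapiens) for inhibition, read by sulforhodamine B assay, with a stated time of 48 h, tested at 10 uM (on this read-out higher numbers stand for more inhibition at the one concentration tested (going by the name of the read-out) and lower numbers for less inhibition), compound 3 gives 17.6%, the second highest of the three numbers. Its nearest neighbour is compound 2, reached by a number 14 percentage points higher from compound 2 to compound 3 (beyond the scatter); its furthest is compound 1, from which it is reached by a number 27.9 percentage points lower from compound 1 to compound 3 (beyond the scatter). The widest spread in the set is a number 41.9 percentage points lower from compound 1 to compound 2 (beyond the scatter).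

Compound 4 `c1cn2cc(-c3ccsc3)nc(-c3ccc4ncn(C5CCCCC5)c4c3)c2n1` is not yet measured. It differs from compound 3 by thiophen-3-yl in place of 4-fluorophenyl on an aromatic carbon. Going by the values given here, two measured steps bear on this: a number 14 percentage points higher from compound 2 to compound 3 (beyond the scatter) shows that a smaller aryl group in this position gave a modestly higher number than the larger naphthalen-1-yl, while a number 27.9 percentage points lower from compound 1 to compound 3 (beyond the scatter) shows that the formyl-bearing ring stood well above the fluoro one. Thiophen-3-yl is smaller still than 4-fluorophenyl and brings one hydrogen-bond acceptor, but no measured pair tests such a change directly. Compound 4 is therefore expected to sit near compound 3, with a step of a number 2.4 percentage points higher from compound 3 to compound 4 (within the scatter) that may lie within the scatter. The estimate for compound 4 is 20%, with a range from 5% to 38%.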

Compound 4, a percentage reported as inhibition, at one concentration (the size of the read-out at that concentration, not a potency): 5.56%
The estimate for compound 4 lay 14.4 percentage points above the measured number, within the range that was stated.
By their numbers in this assay, from the lowest: compounds 2 and 4 (each within the scatter of the next); then compound 3; then compound 1.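

In this assay, moving to a smaller five-membered ring does not hold the level of the 4-fluorophenyl group, with a number 12 percentage points lower from compound 3 to compound 4 (beyond the scatter). The thiophen-3-yl and naphthalen-1-yl groups fall together, with a number 1.9 percentage points higher from compound 2 to compound 4 (within the scatter), so group size alone does not order these compounds, while the 4-formylphenyl group remains well clear of thiophen-3-yl, with a number 39.9 percentage points lower from compound 1 to compound 4 (beyond the scatter). No measurement is available that would account for these differences.

As far as these compounds go, it remains open whether the higher number of compound 1 depends on the formyl group itself or would persist with a carboxylic acid or an amine in its place on the phenyl ring. From the compounds shown here alone, it is also open whether a formyl group on the thiophen-3-yl ring would give a comparable number.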